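Shortening the alkoxy chain on the ring nitrogen toward an ether

The compounds below may be only part of what the source reports. "The series", "measured", "known", "first", "only" and "open" are said of these compounds alone.

Measured so far:
compound 1, `CCCON1C(=O)[C@@H](NC(=O)OCCCCC2CCCCC2)[C@@H]1C`, 133 nM
compound 2, `CCCCCCCON1C(=O)[C@@H](NC(=O)OCCCCC2CCCCC2)[C@@H]1C`, 2230 nM

Among the compounds with values here, compound 2 gives the highest of the two numbers so far in an assay on HEK293 cells for inhibition of N-acylethanolamine-hydrolyzing acid amidase (Homo sapiens), read by fluorescence, with stated times of 10 min and 50 min; a lower number here means a stronger inhibitor, a higher number a weaker inhibitor; its nearest neighbour is compound 1, which gives 133 nM, and the step of a 17-fold higher number from compound 1 to compound 2 (1.22 log units; beyond the scatter) lies beyond the scatter, in the direction of weaker inhibition. Compound 3, `CCOCCON1C(=O)[C@@H](NC(=O)OCCCCC2CCCCC2)[C@@H]1C`, has not yet been measured. It differs from compound 2 by ethoxy in place of pentyl on a saturated chain carbon, two bonds along the chain from an oxygen on an unsaturated carbon; read one bond further out, the change is heptyloxy to 2-ethoxyethoxy.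

Within the data shown here, the only step that bears on this is a 17-fold higher number from compound 1 to compound 2 (1.22 log units; beyond the scatter), where lengthening the chain on the ring nitrogen made the number much larger. Among the measured compounds shown here, compound 3 moves back toward the shorter chain of compound 1, while keeping an oxygen within it, for which no measured step exists. Compound 3 is therefore expected to give a lower number than compound 2, estimated as a 5.0-fold lower number from compound 2 to compound 3 (0.70 log units; beyond the scatter), though probably not as low as compound 1. The estimate for compound 3 is 450 nM, with a range of 130 nM to 1500 nM.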

Compound 3, half-maximal inhibitory concentration: 187 nM
Beside the measured number, compound 3's estimate is 2.4-fold (0.38 log units) above it; the measured number falls inside the stated range.
By their numbers in this assay, from the lowest: compounds 1 and 3 (each within the scatter of the next); then compound 2.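

In this assay, the change from heptyloxy to 2-ethoxyethoxy gives a 12-fold lower number from compound 2 to compound 3 (1.08 log units; beyond the scatter), so this position can return from the weak number of compound 2 to a much lower one while still carrying a chain longer than that of compound 1. The step of a 1.4-fold higher number from compound 1 to compound 3 (0.15 log units; within the scatter) lies within the scatter, which shows that a longer chain here does not always go with a higher number, as the first pair alone might have suggested; a chain with an oxygen in it reads level with the chain of compound 1. Nothing available gives a reason for these numbers.

Heptyloxy and 2-ethoxyethoxy differ in both chain length and the presence of the oxygen, so these compounds leave open which of the two accounts for the large step, a question that a pentyloxy chain in the same place could help to separate. On these data alone, it also remains open how far the chain can grow when it holds an oxygen, and whether a longer ether such as 2-butoxyethoxy, or a chain ending in an amine or a carboxylic acid, would keep the number of compound 3.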